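Replacing a phenyl end group in a mouse assay

The source may report more compounds than this note shows. Statements on the series, on what has been measured and on what is new or still open speak of the compounds shown alone.

Values measured in a functional assay on the whole organism with Mus musculus as the target (on this read-out higher numbers stand for an effect only at larger amounts of compound and lower numbers for an effect already at smaller amounts), are these
Compound 1 `C[C@@H](NCc1ccc(Oc2ccccc2)cc1)C(N)=O` gives 64 mg/kg
Compound 2 `C[C@@H](NCc1ccc(NCc2ccccc2)cc1)C(N)=O` gives 9.3 mg/kg
Compound 3 `CNC(=O)[C@@H](CO)NCc1ccc(OCc2cccc(F)c2)cc1` gives 25.1 mg/kg

Compound 1 with 64 mg/kg carries the highest number of the three. The gaps down to compound 3 with 25.1 mg/kg and further down to compound 2 with 9.3 mg/kg both lie beyond the usual scatter of this assay in this set. No two of these compounds differ in only one place, so no single change has been isolated by measurement.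

The unmeasured compound 4 `C[C@@H](NCc1ccc(OCc2ccsc2)cc1)C(N)=O` departs from compound 1 at one place, and the change is (thiophen-3-yl)methyl in place of phenyl on an oxygen on an aromatic ring with the rest of the structure kept. For the measured compounds named here, no compound measured so far contains this thiophene ring, so the exchange has no direct precedent here. Going by the values given here, the only guidance comes from compound 2 at 9.3 mg/kg and compound 3 at 25.1 mg/kg in which the terminal aromatic ring also hangs on a methylene, although each differs from compound 1 elsewhere too. An expected step of a 4.0-fold lower number from compound 1 to compound 4 (0.60 log units; beyond the scatter) would therefore run toward a lower number and beyond the scatter. For compound 4 the estimated value is 16 mg/kg with an expected range from 6 mg/kg to 40 mg/kg in this assay.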

Compound 4, dose for half-maximal effect: 114 mg/kg
Estimate against measurement, compound 4: 7.1-fold (0.85 log units) below, and the stated range ends below it.
By their numbers in this assay, from the lowest: compound 2; then compound 3; then compounds 1 and 4 (each within the scatter of the next).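

In this assay, for the compounds shown here, the exchange of phenyl for (thiophen-3-yl)methyl on an oxygen on an aromatic ring comes to a 1.8-fold higher number from compound 1 to compound 4 (0.25 log units; within the scatter) and is the only step in this set that isolates a change at one place. The read-out therefore does not separate these two end groups at this position, even though the entering group has a five-membered aromatic ring with a sulfur atom and one hydrogen-bond acceptor, while the leaving phenyl has a six-membered ring of carbon only and no acceptor. Going by these compounds alone, in this one pair, then, placing a thiophene ring on a methylene at this oxygen is a change that the assay tolerates without a shift beyond the scatter, and the single step says nothing about any other end group.

As far as these compounds go, whether a plain benzyl, a (thiophen-2-yl)methyl or a (pyridin-3-yl)methyl at the same oxygen would also stay within the scatter of compound 1 remains open. The compounds shown also offer no measured property that could account for the two end groups reading alike, so the reason for this result stays unknown.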